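The source may hold more compounds than are shown below. What is called first, only, known or untested is meant among the compounds shown, and "the series" means these compounds.

The measured compounds so far are:
compound 1, `O=C(CN1CCCCC1)NCCNc1ccnc2cc(Cl)ccc12`, which gives 23700 nM in a toxicity assay (L6 cells) for inhibition, with Rattus norvegicus as the target, read by resazurin assay, with a stated time of 70 h; a higher number here means a weaker inhibitor, a lower number a stronger inhibitor;
compound 2, `Clc1ccc2c(NCCCN3CCCCCC3)ccnc2c1`, which gives 20000 nM in this assay;
compound 3, `CCCN(CCC)CCN1CCN(c2ccnc3cc(Cl)ccc23)CC1`, which gives 56800 nM in this assay.

Among these three, compound 3 shows the highest number, so it is the weakest inhibitor of the set. Compound 1 stands nearest to it and compound 2 furthest, and both gaps lie beyond the usual scatter of this measurement.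

Compound 4, `Clc1ccc2c(N3CCN(CCN4CCCCCC4)CC3)ccnc2c1`, has not yet been measured. It differs from compound 3 in a single place: azepan-1-yl in place of dipropylamino on a saturated chain carbon, two bonds along the chain from an amine nitrogen in a ring. For the measured compounds named here, no pair of measured compounds differs in only one place, so there is no measured step of this kind to lean on. Compound 2 does carry an azepan-1-yl group at the end of its chain and gives a lower number than compound 3, but it differs from compound 3 in more than one place, so its value alone cannot be read as a guide to this change.

With the shared core kept and only the chain end altered, a modest step toward a lower number is expected, probably not beyond the scatter. The step expected from compound 3 to compound 4 is a 1.4-fold lower number from compound 3 to compound 4 (0.15 log units; within the scatter). For compound 4 the estimate in this assay is 40000 nM, with a range from 15000 nM to 100000 nM.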

Compound 4, half-maximal inhibitory concentration: 25400 nM
Compound 4: the middle estimate sits 1.6-fold (0.20 log units) above what was measured; the measured number falls inside the stated range.
By their numbers in this assay, from the lowest: compounds 2, 1 and 4 (each within the scatter of the next); then compound 3.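

For the compounds shown here, this is the first measured step in the set that changes a single place. In this assay, azepan-1-yl in place of dipropylamino on a saturated chain carbon, two bonds along the chain from an amine nitrogen in a ring, gives a 2.2-fold lower number from compound 3 to compound 4 (0.35 log units; beyond the scatter) and so moves the number by a modest amount. This step lies beyond the usual scatter of the measurement. The two groups hold the same count of carbon and nitrogen atoms, so this position responds to an open pair of chains being replaced by a ring even with no change in those counts, although nothing available here explains the step.

The compounds shown leave open whether a smaller ring such as pyrrolidin-1-yl, a ring carrying an oxygen such as morpholin-4-yl, or shorter open chains such as diethylamino would lower the number further at this place. They also leave open whether the same swap would give a similar step on a chain of a different length, such as a propyl linker in place of the present one.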